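This account rests on a few compounds, and the source may have more. Where it says the series, first, only, none or still open, it means among the compounds named here.

Two compounds share one core and differ only in how it is joined together. Compound 1, `COc1cc(C)cc(-c2c(-c3ccnc(-c4ccc(N(C)C)cc4)c3)cnn2CC#N)c1`, has the dimethylamino-bearing arm on one side of that core, and compound 2, `COc1cc(C)cc(-c2nn(CC#N)cc2-c2ccnc(-c3ccc(N(C)C)cc3)c2)c1`, carries the same pieces in the swapped arrangement. In a functional assay on SF-295 cells (Homo sapiens) for inhibition, read by sulforhodamine B assay, with a stated time of 48 h (a lower number here means a stronger inhibitor of growth, a higher number a weaker inhibitor of growth), compound 1 gives 52.9 nM. In this assay compound 2 gives 304 nM, the higher of the two numbers, so compound 2 is the weaker growth inhibitor of the pair, and the gap to compound 1 lies beyond the usual scatter.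

Compound 3, `Cc1cc(O)cc(-c2nn(CC#N)cc2-c2ccnc(-c3ccc(N(C)C)cc3)c2)c1`, keeps the arrangement of compound 2 and changes a single group: hydrogen in place of methyl on an oxygen on an aromatic ring. Among the compounds with values here, no measured pair shows what this change does here, so nothing points to a direction. The step from compound 2 to compound 3 is therefore expected to be small, a 1.0-fold lower number from compound 2 to compound 3 (0.01 log units; within the scatter), within the scatter. For compound 3 the estimate in this assay is 300 nM, with a range from 100 nM to 900 nM.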

Compound 3, concentration for 50% growth inhibition: 2180 nM
Compound 3: middle estimate off by 7.3-fold (0.86 log units), on the low side, and the stated range ends below it.
By their numbers in this assay, from the lowest: compound 1; then compound 2; then compound 3.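

Changing methoxy to hydroxy on the 3-methoxy-5-methylphenyl group is not a neutral swap here: it gives a 7.2-fold higher number from compound 2 to compound 3 (0.86 log units; beyond the scatter) in this assay and leaves compound 3 the weaker growth inhibitor of the two. Within the data shown here, the earlier pair showed only that the way the core is joined together matters. This pair adds that the methyl on an oxygen on an aromatic ring also matters, at least in the arrangement of compound 2, even though only one carbon leaves. No measurement shown bears on the reason for this step.

As far as these compounds go, whether the same change would have a similar effect in the arrangement of compound 1 remains open. So does the effect of other groups at this position, such as ethoxy or an amine.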